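The source may hold more compounds than are shown below. What is called first, only, known or untested is meant among the compounds shown, and "the series" means these compounds.

Among the measured compounds shown here, in an ADME assay on HepG2 2.2.15 cells (Homo sapiens) for cytotoxicity, read by CCK-8 assay, with a stated time of 8 days (a lower number here means that less compound is tolerated, a higher number that more compound is tolerated), compound 1 (`COc1ccc(-c2cc(NC(=O)c3ccc(Cl)cc3O)c[nH]c2=O)cc1`) gives 50500 nM and compound 2 (`CCOc1ccc(-c2cc(NC(=O)c3ccc(OC)cc3O)c[nH]c2=O)cc1`) gives 69600 nM, which places compound 2 within the scatter of the only other measured compound. Compound 3 (`CCOc1ccc(-c2cc(NC(=O)c3ccc(Cl)cc3O)c[nH]c2=O)cc1`) differs from compound 2 by chloro in place of methoxy on an aromatic carbon. For the measured compounds named here, no measured pair isolates this change. Compound 1 carries the same 4-chloro-2-hydroxyphenyl group and gives 50500 nM, so no shift beyond the scatter is expected. The expected step, a 1.3-fold lower number from compound 2 to compound 3 (0.10 log units; within the scatter), stays within the scatter. For compound 3 the estimated value is 55000 nM, with an expected range of 25000 nM to 120000 nM.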

Compound 3, half-maximal cytotoxic concentration: 28600 nM
Beside the measured number, compound 3's estimate is 1.9-fold (0.28 log units) above it; measured number inside the range.
By their numbers in this assay, from the lowest: compounds 3, 1 and 2 (each within the scatter of the next, the first and the last beyond it).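

At this aromatic carbon, meta to a hydroxy group and para to a large group, chloro in place of methoxy gives a 2.4-fold lower number from compound 2 to compound 3 (0.39 log units; beyond the scatter) in this assay and so lowers the tolerated concentration by a modest step beyond the scatter. By contrast, methyl in place of hydrogen on the saturated chain carbon bound to an oxygen gives a 1.8-fold lower number from compound 1 to compound 3 (0.25 log units; within the scatter) and stays within the scatter. Nothing measured here accounts for the chloro step.

Open, as far as these compounds go, are other groups at the aromatic carbon, such as fluoro, an amine or a carboxylic acid. From the compounds shown here alone, a longer chain on the oxygen also remains open.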